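Methylating the phenol of a 1-aryl isoquinoline-type core

The source may hold more compounds than are shown below. What is called first, only, known or untested is meant among the compounds shown, and "the series" means these compounds.

Compound 1 `COc1ccc(-c2cc3cc(C)ccc3c(-c3cccc(O)c3)n2)cc1OC` and compound 2 `COc1ccc(-c2cc3cc(C)ccc3c(-c3ccc(O)cc3)n2)cc1OC` differ only in the ring carrying the hydroxy, and in a functional assay on T47D cells (Homo sapiens) for cytotoxicity, read by CCK-8 assay and cell counting, with a stated time of 72 h (a lower number here means a stronger inhibitor, a higher number a weaker inhibitor), compound 1 gives 4340 nM while compound 2 gives 4420 nM, so a 1.0-fold higher number from compound 1 to compound 2 (0.01 log units; within the scatter) places compound 2 within the scatter of compound 1, the higher of the two numbers. Compound 3 `COc1ccc(-c2nc(-c3ccc(OC)c(OC)c3)cc3cc(C)ccc23)cc1` carries methyl in place of hydrogen on an oxygen on an aromatic ring. Going by the values given here, no measured step covers a hydroxy-to-methoxy change, so no direction is warranted beyond the scatter; compound 3 is estimated at 5000 nM (range 1500 nM to 16000 nM), a step of a 1.1-fold higher number from compound 2 to compound 3 (0.05 log units; within the scatter) in this assay.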

Compound 3, half-maximal inhibitory concentration: 3340 nM
Compound 3: the middle estimate sits 1.5-fold (0.18 log units) above what was measured; the measured number falls inside the stated range.
By their numbers in this assay, from the lowest: compounds 3, 1 and 2 (each within the scatter of the next).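

In this assay, replacing the hydrogen on the oxygen of this aromatic ring with methyl gives a 1.3-fold lower number from compound 2 to compound 3 (0.12 log units; within the scatter), and the comparison with the 3-hydroxyphenyl compound gives a 1.3-fold lower number from compound 1 to compound 3 (0.11 log units; within the scatter). Across these three compounds, then, the hydroxy hydrogen can be capped as methoxy with no change beyond the scatter, so a free hydroxy on this ring is not required for activity at this level.

From the compounds shown here alone, whether an amine, a carboxylic acid or a longer alkoxy chain at this position would move the number remains open. Nothing available explains why the hydroxy and methoxy compounds read alike.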